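Benzyl in Place of Methoxyphenyl on the Nitrogen

The compounds below may be only part of what the source reports. "The series", "measured", "known", "first", "only" and "open" are said of these compounds alone.

Of the compounds shown here, three built on one shared core have been tested in an assay on NIH3T3 cells with Urotensin-2 receptor (Homo sapiens) as the target; a lower number here means that less compound is needed, a higher number that more compound is needed for the effect. Compound 1 `Cc1cc(Br)ccc1C(=O)OC(CCN(C)C)c1ccc(Cl)cc1` gives 1070 nM. Compound 2 `Cc1ccccc1NC(=O)OC(CCN(C)C)c1ccc(Cl)cc1` gives 3890 nM, a change of a 3.6-fold higher number from compound 1 to compound 2 (0.56 log units; beyond the scatter). Compound 3 `COc1ccc(NC(=O)OC(CCN(C)C)c2ccc(Cl)cc2)cc1` gives 1660 nM, a change of a 2.3-fold lower number from compound 2 to compound 3 (0.37 log units; beyond the scatter). Among these three numbers, compound 3 holds the second highest: its number and that of compound 1 sit within the usual scatter of each other, while compound 2 lies beyond it.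

Compound 4 `CN(C)CCC(OC(=O)NCc1ccccc1)c1ccc(Cl)cc1` differs from compound 3 in one place: benzyl in place of 4-methoxyphenyl on an amide-type nitrogen. Within the data shown here, the only measured step at this nitrogen is a 2.3-fold lower number from compound 2 to compound 3 (0.37 log units; beyond the scatter), a modest one, and no measured compound carries a benzyl there, so the data give no direct guide for this group. A modest step in this assay is therefore expected, with the direction uncertain and a somewhat higher number slightly favoured. Compound 4 is estimated at 2500 nM, with a range from 800 nM to 8000 nM, which is expected to correspond to a step of a 1.5-fold higher number from compound 3 to compound 4 (0.18 log units; within the scatter).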

Compound 4, half-maximal effective concentration: 2140 nM
For compound 4 the middle estimate is 1.2-fold (0.07 log units) above the measured one; the measured number falls inside the stated range.
By their numbers in this assay, from the lowest: compounds 1, 3, 4 and 2 (each within the scatter of the next, the first and the last beyond it).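

Benzyl on the amide-type nitrogen, which has no oxygen and no hydrogen-bond acceptor, leaves the number in this assay within the scatter of compound 3 (a 1.3-fold higher number from compound 3 to compound 4 (0.11 log units; within the scatter)), so the methoxy oxygen of compound 3 is not needed to keep a number of this size. Benzyl also stays within the scatter of the 2-methylphenyl group (a 1.8-fold lower number from compound 2 to compound 4 (0.26 log units; within the scatter)), although the two aryl groups at this nitrogen differ beyond it, and the same holds for the change from compound 1 with its 4-bromo-2-methylphenyl group (a 2.0-fold higher number from compound 1 to compound 4 (0.30 log units; within the scatter)). No measurement shown here explains these results.

Still open, going by these compounds, is how a longer chain between the ring and the nitrogen would behave. An amine or a carboxylic acid on the benzyl ring also remains untested among these compounds.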